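Replacing 2-hydroxypropyl with a carbonyl group on oxygen

The compounds below may be only part of what the source reports. "The series", "measured", "known", "first", "only" and "open" are said of these compounds alone.

Compound 1 `CC(C)=CC[C@@H](OC(=O)CCO)C1=CC(=O)c2c(O)ccc(O)c2C1=O`: 67600 nM
Compound 2 `CC(C)=CC[C@@H](OC(=O)c1ccco1)C1=CC(=O)c2c(O)ccc(O)c2C1=O`: 80300 nM
Compound 3 `CC(C)=CC[C@@H](OCC(C)O)C1=CC(=O)c2c(O)ccc(O)c2C1=O`: 24700 nM

These values come from a functional assay on HeLa cells (Homo sapiens) for cytotoxicity, read by MTT assay; on this read-out lower numbers stand for stronger inhibition and higher numbers for weaker inhibition. Compound 3 has the lowest number of the three, beyond the scatter from both others. Compound 4 `CCCC(C)(O)CC(=O)O[C@H](CC=C(C)C)C1=CC(=O)c2c(O)ccc(O)c2C1=O` has not yet been measured. Its change from compound 3 is (2-hydroxy-2-methylpentyl)carbonyl in place of 2-hydroxypropyl on an oxygen on a saturated carbon, with (2-hydroxy-2-methylpentyl)carbonyl in place of 2-hydroxypropyl on an oxygen on a saturated carbon. Compound 1 and compound 2 also carry a carbonyl group on that oxygen, so two steps bear on this change when read backwards: a 2.7-fold lower number from compound 1 to compound 3 (0.44 log units; beyond the scatter) and a 3.3-fold lower number from compound 2 to compound 3 (0.51 log units; beyond the scatter). Exchanging those two carbonyl groups gave a 1.2-fold higher number from compound 1 to compound 2 (0.07 log units; within the scatter). Among the measured compounds shown here, no measured compound carries this longer chain, so the expectation is uncertain. The expected step is a 2.2-fold higher number from compound 3 to compound 4 (0.35 log units; beyond the scatter). The estimated value for compound 4 is 55000 nM, with an expected range of 22000 nM to 120000 nM.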

Compound 4, half-maximal inhibitory concentration: 72000 nM
The estimate for compound 4 lay 1.3-fold (0.12 log units) below the measured number, and the stated range covers the measured number.
By their numbers in this assay, from the lowest: compound 3; then compounds 1, 4 and 2 (each within the scatter of the next).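

In this assay, the step to the carbonyl group on this oxygen recurs with a third, much larger chain: a 2.9-fold higher number from compound 3 to compound 4 (0.46 log units; beyond the scatter). The two comparisons among carbonyl compounds both stay within the scatter: a 1.1-fold higher number from compound 1 to compound 4 (0.03 log units; within the scatter) and a 1.1-fold lower number from compound 2 to compound 4 (0.05 log units; within the scatter). Thus 2-hydroxy-2-methylpentyl, furan-2-yl and 2-hydroxyethyl on the carbonyl carbon cannot be told apart here, and compound 3 alone stands apart from these three.

Going by these compounds, whether an amine or a carboxylic acid at the end of that chain, or a longer chain on the oxygen without the carbonyl, would shift the number remains open. Nothing available explains the gap between compound 3 and the carbonyl compounds.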